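The source may report more compounds than this note shows. Statements on the series, on what has been measured and on what is new or still open speak of the compounds shown alone.

In a functional assay on HL-60 cells (Homo sapiens) for cytotoxicity, read by MTT assay, with a stated time of 96 h (a lower number here means a stronger inhibitor, a higher number a weaker inhibitor), three compounds sharing a core have been measured. Compound 1 (`CC[C@H](NC)C(=O)N[C@@H]1C(=O)N2[C@@H](CC[C@@H]1CN)CC[C@H]2C(=O)NC(c1ccccc1)c1ccccc1`) gives 51800 nM, compound 2 (`CC[C@H](N)C(=O)N[C@@H]1C(=O)N2[C@@H](CC[C@@H]1CNC(=O)NCc1ccccc1)CC[C@H]2C(=O)NC(c1ccccc1)c1ccccc1`) gives 51000 nM, and compound 3 (`CC[C@H](NC)C(=O)N[C@@H]1C(=O)N2[C@@H](CC[C@@H]1CCNC(=O)c1ccccc1)CC[C@H]2C(=O)NC(c1ccccc1)c1ccccc1`) gives 32600 nM. Compound 2 thus lies within the scatter of both other compounds, and the three numbers cannot be ranked.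

Compound 4 (`CCNCC[C@H]1CC[C@H]2CC[C@@H](C(=O)NC(c3ccccc3)c3ccccc3)N2C(=O)[C@H]1NC(=O)[C@@H](N)CC`) departs from compound 2 in one place: (ethylamino)methyl in place of (benzylcarbamoyl)amino on a saturated chain carbon bound to a saturated ring carbon. In words, this is (ethylamino)methyl in place of (benzylcarbamoyl)amino on a saturated chain carbon bound to a saturated ring carbon.

For the measured compounds named here, no measured compound carries this exact change, so the evidence is indirect. Going by the values given here, the one measured single-place step at this kind of carbon is a 1.6-fold lower number from compound 1 to compound 3 (0.20 log units; within the scatter), where benzamidomethyl stands in place of amino. That step is small even though a benzene ring enters with the new group. Compound 1 and compound 2 differ in more than one place, yet their values also lie within the scatter of each other. On this limited evidence, no change beyond the scatter is expected in this assay, and the expected step is a 1.1-fold lower number from compound 2 to compound 4 (0.05 log units; within the scatter). For compound 4 the estimated value is 45000 nM, with an expected range of 22000 nM to 90000 nM.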

Compound 4, half-maximal inhibitory concentration: 62800 nM
Estimate against measurement, compound 4: 1.4-fold (0.14 log units) below, within the range that was stated.
By their numbers in this assay, from the lowest: compounds 3, 2, 1 and 4 (each within the scatter of the next).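

In this assay, the exchange of (benzylcarbamoyl)amino for (ethylamino)methyl on a saturated chain carbon bound to a saturated ring carbon gives a 1.2-fold higher number from compound 2 to compound 4 (0.09 log units; within the scatter). This shows that a much smaller group, with fewer heavy atoms and with no ring, leaves the number within the scatter, even though the six-membered aromatic ring of carbon only and a double bond outside aromatic rings both go. The earlier step, a 1.6-fold lower number from compound 1 to compound 3 (0.20 log units; within the scatter), showed only a larger group with a benzene ring entering at this kind of carbon, so the two steps now cover both an added and a removed aromatic ring, and no evidence shown here accounts for these small steps.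

The compounds shown leave open whether a carboxylic acid or a dimethylamino group at this place would give a step beyond the scatter. For the compounds shown here, they also leave open the separate contribution of the methylamino and amino groups that distinguish compound 1 and compound 3 from compound 2 and compound 4, as no pair here differs in that place alone.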